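Removing the Amino Group from the Pyrazole Ring

The compounds below may be only part of what the source reports. "The series", "measured", "known", "first", "only" and "open" are said of these compounds alone.

Measured compounds:
- compound 1, `Fc1ccc(-c2nn3c(NC4CCCC4)cccc3c2-c2ccnnc2)cc1`: "not determined" (no result reported)
- compound 2, `Nc1n[nH]cc1-c1c(-c2ccc(F)cc2)nn2c(NC3CCCC3)cccc12`: 20000 nM

Going by the values given here, only two compounds have been examined here, and only one of them carries a number. In an ADME assay on Vero cells (Chlorocebus sabaeus) for cytotoxicity (on this read-out lower numbers stand for higher toxicity in this test and higher numbers for lower toxicity in this test), compound 2 gives 20000 nM. Compound 1 was entered in this assay as well, but for compound 1 the outcome is "not determined" (no result reported), so compound 2 stands alone as the single measured point and cannot be ranked against anything.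

Compound 3, `Fc1ccc(-c2nn3c(NC4CCCC4)cccc3c2-c2cn[nH]c2)cc1`, is the next member to be tested. It differs from compound 2 in one place only: hydrogen in place of amino on an aromatic carbon of the shared core. Among the compounds with values here, no step between two measured compounds is available to calibrate what such a change does in this assay, so the expectation rests on compound 2 alone.

Given that compound 2 gives 20000 nM, the step from compound 2 to compound 3 is expected to be small, no change at the digits printed from compound 2 to compound 3 (within the scatter), with no clear direction beyond the usual scatter. Compound 3 is therefore estimated at 20000 nM, within a range from 8000 nM to 50000 nM.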

Compound 3, half-maximal cytotoxic concentration: 10000 nM
Compound 3: the middle estimate sits 2.0-fold (0.30 log units) above what was measured; low and high end bracket the measured number.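

In this assay, going by these compounds alone, replacing 3-amino-1H-pyrazol-4-yl with 1H-pyrazol-4-yl gives a 2.0-fold lower number from compound 2 to compound 3 (0.30 log units; within the scatter), which provides the first readable step at this position. On this read-out, the amino group on this aromatic carbon of the five-membered ring can therefore give way to hydrogen without a difference that stands beyond the scatter, and the two compounds cannot be told apart. This holds for this single pair only, and nothing available accounts for the outcome in terms of the group itself.

Compound 1 offers no number, so the steps that would involve it cannot be read, and the comparison at this position rests on compound 2 and compound 3 alone. Going by these compounds, it remains open whether a methyl group, a hydroxyl group, a dimethylamino group or a carboxylic acid on this same aromatic carbon would also stay within the scatter of compound 3 or would move the read-out clearly in either direction, and whether the exchange of amino for hydrogen would read the same way on a different core.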